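The source may report more compounds than this note shows. Statements on the series, on what has been measured and on what is new or still open speak of the compounds shown alone.

Of the compounds shown here, three have so far been measured in a functional assay on CHO cells for antagonist activity at Orexin/Hypocretin receptor type 1 (Homo sapiens), read by FLIPR and calcium flux; a lower number here means a stronger inhibitor, a higher number a weaker inhibitor. Compound 1 `CNC(=O)[C@@H](c1ccccc1)N1CCn2c(CC3CC3)nc(Cl)c2[C@@H]1CCc1ccc(C(F)(F)F)cc1` gives 1430 nM in this assay. Compound 2 `CCc1nc(C(F)(F)F)c2n1CCN([C@@H](C(=O)NC)c1ccccc1)[C@H]2CCc1ccc(C(F)(F)F)cc1` gives 1070 nM in this assay. Compound 3 `C=Cc1nc(CC)n2c1C(CCc1ccc(C(F)(F)F)cc1)N([C@@H](C(=O)NC)c1ccccc1)CC2` gives 150 nM in this assay, the lowest of the three numbers; its gap to compound 2 and its wider gap to compound 1 both lie beyond the usual scatter of repeated measurements, so compound 3 is the strongest inhibitor among the three measured compounds. Compound 4 `CCc1nc(OC)c2n1CCN([C@@H](C(=O)NC)c1ccccc1)C2CCc1ccc(C(F)(F)F)cc1` has not yet been measured. It differs from compound 3 in a single place: methoxy in place of vinyl on an aromatic carbon. For the measured compounds named here, no pair of measured compounds differs in exactly this way, so no measured step shows how large an effect this exchange has. The two other measured compounds differ from compound 3 in more than one place, and both give higher numbers than compound 3 in this assay. On this basis the account expects a modest step toward a higher number, estimated as a 2.7-fold higher number from compound 3 to compound 4 (0.43 log units; beyond the scatter) in this assay, with a fair chance that the change stays within the scatter. The estimate for compound 4 in this assay is therefore 400 nM, expected to lie between 120 nM and 1500 nM.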

Compound 4, half-maximal inhibitory concentration: 134 nM
Compound 4: the middle estimate sits 3.0-fold (0.47 log units) above what was measured, within the range that was stated.
By their numbers in this assay, from the lowest: compounds 4 and 3 (each within the scatter of the next); then compounds 2 and 1 (each within the scatter of the next).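

In this assay, the exchange of vinyl for methoxy on this aromatic carbon of the five-membered aromatic ring gives a 1.1-fold lower number from compound 3 to compound 4 (0.05 log units; within the scatter), the first step measured at this position. The two groups are equal in heavy-atom count but differ in what they carry: vinyl has only carbon and a double bond outside aromatic rings, whereas methoxy brings oxygen and a hydrogen-bond acceptor, and this exchange leaves the number within the scatter. In this pair, then, the position accepts either group without a change that can be told from the scatter, although no measurement shown here offers an explanation for this result.

This single step does not show whether the same holds for groups of a different size or kind on this aromatic carbon, such as an amine, a nitrile or a longer chain like propoxy. It also leaves open whether methoxy and vinyl would still match if the ethyl group elsewhere on the ring were exchanged for another group.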